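This account rests on a few compounds, and the source may have more. Where it says the series, first, only, none or still open, it means among the compounds named here.

Three measured compounds share one core and differ only in the group attached to a carbonyl carbon next to an amide-type nitrogen. Compound 1 `CCC(=O)Nc1ccc(N2CCN(c3ccc(OC[C@@H]4CO[C@@](Cn5cncn5)(c5ccc(Cl)cc5Cl)O4)cc3)CC2)cc1` carries a propanoyl group there. In a toxicity assay on L02 cells (Homo sapiens) for inhibition, read by MTT assay, with a stated time of 48 h (on this read-out lower numbers stand for stronger inhibition and higher numbers for weaker inhibition), compound 1 reaches only a limit of the measurement, reported as > 50000 nM. Compound 2 `O=C(CCc1ccccc1)Nc1ccc(N2CCN(c3ccc(OC[C@@H]4CO[C@@](Cn5cncn5)(c5ccc(Cl)cc5Cl)O4)cc3)CC2)cc1` also sits at a limit, giving > 50000 nM in this assay. Compound 3 `O=C(Nc1ccc(N2CCN(c3ccc(OC[C@@H]4CO[C@@](Cn5cncn5)(c5ccc(Cl)cc5Cl)O4)cc3)CC2)cc1)c1cccc(F)c1` likewise gives only a limit, > 50000 nM in this assay, so it stands level with the other two and no order among them can be read. The step that the two limits leave unreadable from compound 1 to compound 2 cannot be sized, nor can a step that the two limits leave unreadable from compound 1 to compound 3 or a step that the two limits leave unreadable from compound 2 to compound 3, since all three values sit together at the limit of > 50000 nM in this assay, at which 3 of the 3 values shown sit.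

Compound 4 `O=C(Nc1ccc(N2CCN(c3ccc(OC[C@@H]4CO[C@@](Cn5cncn5)(c5ccc(Cl)cc5Cl)O4)cc3)CC2)cc1)c1ccco1` differs from compound 3 by furan-2-yl in place of 3-fluorophenyl on a carbonyl carbon. For the measured compounds named here, none of the measured steps gives a readable size for a change of this kind, and every value so far lies at the same limit. The expected step is therefore a number no higher from compound 3 to compound 4 (the limit leaves the size open), with no move beyond the scatter. Compound 4 is expected to show about 50000 nM in this assay, most likely again reported only as a limit, in the range 20000 nM to 120000 nM.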

Compound 4, half-maximal inhibitory concentration: > 50000 nM
Compound 4: no number, only a limit; the forecaster's own chance of this, stated with the estimate: 85%; the middle value lies on the limit itself.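

In this assay compound 4 gives > 50000 nM, which is a limit and not a number. The steps from compound 1, compound 2 and compound 3 to compound 4 therefore cannot be read, as all four compounds sit together: the limit of > 50000 nM in this assay, at which 4 of the 4 values shown sit.

The compounds shown leave open how strongly any of them inhibits these cells, and whether the group on the carbonyl carbon changes that at all.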